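Compound 3 to compound 4: fluoro to hydroxy

This account rests on a few compounds, and the source may have more. Where it says the series, first, only, none or still open, it means among the compounds named here.

compound 1 `O=S(=O)(Nc1ccc(-c2nc3ccccc3o2)cc1)c1ccc(Cl)s1`: > 100000 nM
compound 2 `O=S(=O)(Nc1ccc(-c2nc3ccccc3o2)cc1)c1ccccc1Cl`: > 100000 nM
compound 3 `O=S(=O)(Nc1ccc(-c2nc3ccccc3o2)cc1)c1ccccc1F`: > 100000 nM

All three entries from an ADME assay on HEK293 cells (Homo sapiens) for cytotoxicity, read by resazurin assay, with a stated time of 48 h (a higher number here means that more compound is tolerated, a lower number that less compound is tolerated), are limits, not numbers (the limit of > 100000 nM in this assay, at which 3 of the 3 values shown sit). Compound 3 stands at > 100000 nM, which is a limit. Compound 4 `O=S(=O)(Nc1ccc(-c2nc3ccccc3o2)cc1)c1ccccc1O` carries hydroxy in place of fluoro on an aromatic carbon, ortho to a large group (hydroxy in place of fluoro on an aromatic carbon). The measured steps bearing on this are a step that the two limits leave unreadable from compound 2 to compound 3 and a step that the two limits leave unreadable from compound 1 to compound 3, and the same holds for a step that the two limits leave unreadable from compound 1 to compound 2, so none gives a size. No step beyond the scatter can be derived from them, and none is expected in this assay in either direction. The expected step is a number no higher from compound 3 to compound 4 (the limit leaves the size open) as an estimate. Compound 4 is expected at 100000 nM, with an estimated range of 40000 nM to 200000 nM and a good chance of another limit.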

Compound 4, half-maximal cytotoxic concentration: > 100000 nM
Compound 4 ended at the assay's limit (the forecaster's own chance of this, stated with the estimate: 75%); the middle value sits exactly at the limit.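

In this assay, no step can be read between compound 4 and compound 1, compound 2 or compound 3, because all four stand at one limit: the limit of > 100000 nM in this assay, at which 4 of the 4 values shown sit.

On these data alone, whether these four compounds differ at all in the concentration tolerated stays open.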